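Hydroxy-bearing aryl hydrazone in a pyridyl oxadiazole series

A few compounds are considered here, and "the series" means these few. Any claim that something is new, unique, unknown or untested is made for them only; others in the source may bear on it.

Of the compounds shown here, three sharing one core have been measured in a functional assay on BGC-823 cells (Homo sapiens) for cytotoxicity, read by MTT assay, with a stated time of 48 h; on this read-out higher numbers stand for weaker inhibition and lower numbers for stronger inhibition. Compound 1 `O=C(CSc1nnc(-c2ccncc2)o1)N/N=C/c1ccc(Cl)cc1` gives 20500 nM. Compound 2 `O=C(CSc1nnc(-c2ccncc2)o1)N/N=C/c1ccc(O)cc1` gives 7940 nM, and the change a 2.6-fold lower number from compound 1 to compound 2 (0.41 log units; beyond the scatter). Compound 3 `COc1cccc(/C=N/NC(=O)CSc2nnc(-c3ccncc3)o2)c1` gives 15800 nM; against compound 1 the step is a 1.3-fold lower number from compound 1 to compound 3 (0.11 log units; within the scatter), and the step of a 2.0-fold higher number from compound 2 to compound 3 (0.30 log units; within the scatter). Compound 3 thus stands second highest of the three numbers, close to compound 1 and separated from compound 2 only by a gap within the scatter.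

Compound 4 `O=C(CSc1nnc(-c2ccncc2)o1)N/N=C/c1cc(Cl)ccc1O` differs from compound 3 by 5-chloro-2-hydroxyphenyl in place of 3-methoxyphenyl on a carbon with a double bond to nitrogen. Among the measured compounds shown here, the only step that bears on this change is the one in which a hydroxy entered, a 2.6-fold lower number from compound 1 to compound 2 (0.41 log units; beyond the scatter), which was modest and beyond the scatter; compound 4 keeps a chloro alongside the new hydroxy, and the step from compound 2 to compound 3 was within the scatter. A modest lowering is therefore expected, a 1.6-fold lower number from compound 3 to compound 4 (0.20 log units; within the scatter). Compound 4 is estimated at 10000 nM, within a range from 4000 nM to 25000 nM.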

Compound 4, half-maximal inhibitory concentration: 5470 nM
Compound 4: middle estimate off by 1.8-fold (0.26 log units), on the high side; the measured number falls inside the stated range.
By their numbers in this assay, from the lowest: compounds 4, 2, 3 and 1 (each within the scatter of the next, the first and the last beyond it).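

With a 2.9-fold lower number from compound 3 to compound 4 (0.46 log units; beyond the scatter) and a 3.7-fold lower number from compound 1 to compound 4 (0.57 log units; beyond the scatter) in this assay, the 5-chloro-2-hydroxyphenyl group is separated beyond the scatter from both the 3-methoxyphenyl and the 4-chlorophenyl groups, whereas compound 2 was separated beyond the scatter only from compound 1. A chloro on the ring therefore does not undo the lower number seen with a hydroxy at this position, at least in this pair of hydroxy-bearing compounds. However, a 1.5-fold lower number from compound 2 to compound 4 (0.16 log units; within the scatter) lies within the scatter, so compound 2 and compound 4 cannot be told apart, and nothing available accounts for these steps.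

The compounds shown leave open whether the hydroxy alone would give the same number with its chloro removed from the 5-chloro-2-hydroxyphenyl group. They also leave open how an amine or a carboxylic acid in place of that hydroxy would read.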